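The source may report more compounds than this note shows. Statements on the series, on what has been measured and on what is new or still open speak of the compounds shown alone.

Measured compounds:
compound 1, `CCCCCCCCCCCCCCCCCCCc1c(C)c(N(C)C)nc(C)c1O` — 42%
compound 2, `CCCCCCCCCCCCCCCCc1nc(N(C)C)c(C)c(C)c1O` — 84%

Of the compounds shown here, two have been measured in a functional assay on cells (Lymphocyte, Homo sapiens) for inhibition, read by flow cytometry, using a membrane potential dye, with a stated time of 16 h, tested at 250 nM; a lower number here means a weaker effect, a higher number a stronger effect of the compound at the concentration tested. Compound 1 `CCCCCCCCCCCCCCCCCCCc1c(C)c(N(C)C)nc(C)c1O` gives 42%, and compound 2 `CCCCCCCCCCCCCCCCc1nc(N(C)C)c(C)c(C)c1O` gives 84%. Of these two numbers, compound 1 stands lowest; its nearest neighbour is compound 2, whose value lies higher by a gap beyond the usual scatter. Among the measured compounds shown here, the two measured compounds differ in several places at once, so no single-point step between them is available to guide the next comparison.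

Compound 3 `CCCCCCCCCCc1c(C)c(N(C)C)nc(C)c1O` is derived from compound 1 by the change (hydrogen in place of nonyl on a saturated chain carbon, ten or more bonds along the chain from an aromatic carbon). For the measured compounds named here, no measured step of this kind exists here, so the expectation rests on the value of compound 1 alone and on the size of the chain removed. Within the scatter, the outcome could also be no change at all. The step of a number 17 percentage points lower from compound 1 to compound 3 (beyond the scatter) is expected to be a decrease somewhat beyond the scatter. Compound 3 is therefore estimated in this assay at 25%, with a range from 5% to 50%.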

Compound 3, a percentage reported as activity, at one concentration (the size of the read-out at that concentration, not a potency): 78%
For compound 3 the middle estimate is 53 percentage points below the measured one; the measured number lies above the stated range.
By their numbers in this assay, from the lowest: compound 1; then compounds 3 and 2 (each within the scatter of the next).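

In this assay, hydrogen in place of nonyl on a saturated chain carbon, ten or more bonds along the chain from an aromatic carbon, comes with a number 36 percentage points higher from compound 1 to compound 3 (beyond the scatter). Among the compounds shown here, this is the only comparison so far that changes a single place, and it shows that, for this pair with the core unchanged, the nonyl portion is not required for the effect seen at the tested concentration, and that the compound keeping it has the weaker effect. No supporting measurement bears on this step, so its origin remains unexplained.

The pair leaves open how the read-out behaves for chains shorter than that of compound 3 and for lengths between those of the two compounds, since a single step cannot show whether the change with length is gradual or abrupt. It also leaves open what a carboxylic acid or an amine would do in place of nonyl on that same saturated chain carbon, and whether the same shortening would have a similar effect on the core of compound 2.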